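One measured step guides an estimate for a new analogue

A few compounds are considered here, and "the series" means these few. Any claim that something is new, unique, unknown or untested is made for them only; others in the source may bear on it.

In a functional assay for inhibition, with Homo sapiens as the target (a lower number here means tighter binding, a higher number weaker binding), compound 1 `CC(C)(Oc1ccc(F)cc1[N+](=O)[O-])C1OCC(C/C=C\CCC(=O)O)C(c2cccnc2)O1` reads 2.51 nM and compound 2 `Cc1ccc(SC(C)(C)C2OCC(C/C=C\CCC(=O)O)C(c3cccnc3)O2)c([N+](=O)[O-])c1` reads 158 nM as the higher of the two numbers. The change to compound 3 `CC(C)(Cc1ccc(F)cc1)C1OCC(C/C=C\CCC(=O)O)C(c2cccnc2)O1` from compound 2 is a group of 8 heavy atoms (7 carbon, 1 fluorine; one six-membered aromatic ring of carbon only) in place of a group of 11 heavy atoms (7 carbon, 1 nitrogen, 2 oxygen, 1 sulfur; one six-membered aromatic ring of carbon only), on a saturated chain carbon bound to two saturated chain carbons and a saturated ring carbon and the entering group is named 4-fluorobenzyl. Going by the values given here, the only measured step at that place is a 63-fold higher number from compound 1 to compound 2 (1.80 log units; beyond the scatter) and it shows how large a change there can be, though this new group itself is untested. In this assay a smaller step toward a lower number is expected, with a 4.0-fold lower number from compound 2 to compound 3 (0.60 log units; beyond the scatter) as the estimate. Compound 3 is estimated at 40 nM with a range from 6 nM to 250 nM as the expected bounds.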

Compound 3, dissociation constant: 89.1 nM
The estimate for compound 3 lay 2.2-fold (0.35 log units) below the measured number; measured number inside the range.
By their numbers in this assay, from the lowest: compound 1; then compounds 3 and 2 (each within the scatter of the next).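

In this assay, the 4-fluorobenzyl group gives a 1.8-fold lower number from compound 2 to compound 3 (0.25 log units; within the scatter), so the scatter does not separate these two different groups on the saturated chain carbon. The other step, a 35-fold higher number from compound 1 to compound 3 (1.55 log units; beyond the scatter), shows that the large gap first seen with compound 2 also holds for a second group, leaving the group of compound 1 apart from both. No supporting evidence bears on this result. Which atoms of the group in compound 1 account for its lower number stays open. So does how an amine or a carboxylic acid would read at this place.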